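Trifluoromethoxy to Cyano: What to Expect for Compound 4

The source may report more compounds than this note shows. Statements on the series, on what has been measured and on what is new or still open speak of the compounds shown alone.

Of the compounds shown here, three have been measured in an assay on cells for inhibition of Palmitoleoyl-protein carboxylesterase NOTUM variant C330S (Homo sapiens), read by fluorescence, with a stated time of 40 min; on this read-out higher numbers stand for weaker inhibition and lower numbers for stronger inhibition. Compound 1 `Cc1cc(C(=O)O)c(C)n1-c1cccc(C2CC2)c1F` gives 200 nM. Compound 2 `CC(C)c1cccc(N2CCC(C(=O)O)C2)c1` gives 57000 nM, and compound 3 `O=C(O)C1CCN(c2cccc(OC(F)(F)F)c2)C1` gives 63000 nM. Compound 3 thus carries the highest of the three numbers; compound 2 sits within the scatter of it, while compound 1 lies far lower, beyond the scatter. Among the measured compounds shown here, the only measured step between close neighbours runs a 1.1-fold higher number from compound 2 to compound 3 (0.04 log units; within the scatter), a swap of one group on an aromatic carbon that left the number essentially where it was.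

Compound 4 `N#Cc1cccc(N2CCC(C(=O)O)C2)c1` has not yet been measured. It differs from compound 3 in one place: cyano in place of trifluoromethoxy on an aromatic carbon. This is again a swap of a single group on an aromatic carbon, so the earlier step is the one that bears on it. Because the step of a 1.1-fold higher number from compound 2 to compound 3 (0.04 log units; within the scatter) stayed within the scatter, the expected step for compound 4 in this assay is a 1.3-fold lower number from compound 3 to compound 4 (0.10 log units; within the scatter), with no clear direction. Compound 4 is therefore estimated at 50000 nM, within a range from 15000 nM to 150000 nM.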

Compound 4, half-maximal inhibitory concentration: 42000 nM
Compound 4: the middle estimate sits 1.2-fold (0.08 log units) above what was measured; the measured number falls inside the stated range.
By their numbers in this assay, from the lowest: compound 1; then compounds 4, 2 and 3 (each within the scatter of the next).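

Cyano now joins isopropyl and trifluoromethoxy on this aromatic carbon, and in this assay the new group gives a step within the scatter from each of the other two (a 1.5-fold lower number from compound 3 to compound 4 (0.18 log units; within the scatter); a 1.4-fold lower number from compound 2 to compound 4 (0.13 log units; within the scatter)). This extends the earlier finding to a group of a different make-up: cyano has 2 heavy atoms and a triple bond, trifluoromethoxy has 5 heavy atoms including 3 fluorine, and the assay cannot tell them apart on this core. No measurement here explains why these groups read alike.

Going by these compounds, whether a hydroxyl group or a longer alkyl chain on this carbon would shift the number remains open. So does whether these same swaps would also stay within the scatter on the core of compound 1 (200 nM).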